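Two Antagonists at Full Response and a Combined Analogue

The source may hold more compounds than are shown below. What is called first, only, known or untested is meant among the compounds shown, and "the series" means these compounds.

Compound 1, with structure `CNC(=O)[C@@]12CN[C@@H]([C@H](n3cnc4c(N)ncnc43)O1)[C@@H]2O`, and compound 2, with structure `OC[C@@]12CN[C@@H]([C@H](n3cnc4c(NCc5cccc(I)c5)ncnc43)O1)[C@@H]2O`, share the same core and differ at two places at once. In a functional assay for antagonist activity at adenosine receptor A3 (Homo sapiens), with a stated time of 30 min (on this read-out higher numbers stand for larger maximal responses and lower numbers for smaller maximal responses), compound 1 gives 100%. In this assay compound 2 gives 100%, level with compound 1 at the digits shown and within the scatter of the assay, so the two values show no difference in how large a response they reach. Compound 3, with structure `CNC(=O)[C@@]12CN[C@@H]([C@H](n3cnc4c(NCc5cccc(I)c5)ncnc43)O1)[C@@H]2O`, keeps the iodobenzyl group of compound 2 and alters its saturated ring: methylcarbamoyl in place of hydroxymethyl on a saturated ring carbon. For the measured compounds named here, since no step between measured compounds is known and both reach the same maximal response, compound 3 is expected to change little, with an estimated step of no change at the digits printed from compound 2 to compound 3 (within the scatter), no change beyond the scatter in either direction. Compound 3 is therefore estimated to give 100%, between 88% and 106%.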

Compound 3, largest response reached (reported as Imax), in percent of the reference or control that the assay uses: 100%
The estimate for compound 3 equals the measured number at the digits printed; the measured number falls inside the stated range.
By their numbers in this assay, from the lowest: compounds 1, 2 and 3 (each within the scatter of the next).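

For the compounds shown here, compound 3 offers the first comparisons in which only one place differs. In this assay, methylcarbamoyl in place of hydroxymethyl on a saturated ring carbon gives a clean reading (no change at the digits printed from compound 2 to compound 3 (within the scatter)), and so does 3-iodobenzyl in place of hydrogen on a nitrogen on an aromatic ring (no change at the digits printed from compound 1 to compound 3 (within the scatter)), so neither change, taken alone, shifts the largest response reached, which the two-place difference between compound 1 and compound 2 could not show. No available evidence bears on why the response stays level.

Still open, as far as these compounds go, is whether a carboxylic acid or a longer chain on the same saturated ring carbon would leave the largest response level too. The same question applies to an unsubstituted benzyl group on the aromatic-ring nitrogen.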